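The source may hold more compounds than are shown below. What is called first, only, known or untested is meant among the compounds shown, and "the series" means these compounds.

Compounds measured in this study:
compound 1, `CCCCNc1cccc(NC(=O)c2ccc(OCCC)cc2)n1`: 54100 nM
compound 2, `CCCCCNc1cccc(NC(=O)c2ccc(OCCC)cc2)n1`: a limit, > 100000 nM
compound 3, `C=CCOc1ccc(C(=O)Nc2cccc(NCCC)n2)cc1`: 14800 nM

In an in vitro assay on HEK-tsA201 cells for antagonist activity at Neuronal acetylcholine receptor; alpha4/beta2 (Homo sapiens), read by fluorescence and calcium flux (on this read-out lower numbers stand for stronger inhibition and higher numbers for weaker inhibition), compound 1 gives 54100 nM. For compound 2 this assay reports no number but only a limit, > 100000 nM. The change between them is methyl in place of hydrogen on a saturated chain carbon, four bonds along the chain from a nitrogen on an aromatic ring, and it brought an at least 1.8-fold higher number from compound 1 to compound 2 (0.26 log units; that floor lies within the scatter). That step is a floor because of the limit of > 100000 nM in this assay, at which 1 of the 3 values shown sits. Compound 3 gives 14800 nM in this assay, the lowest number among the measured compounds; how its core differs from that of compound 1 is not broken down here.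

Compound 4, `C=CCOc1ccc(C(=O)Nc2cccc(NCCCC)n2)cc1`, is not yet measured. It differs from compound 3 by methyl in place of hydrogen on a saturated chain carbon, three bonds along the chain from a nitrogen on an aromatic ring. This is the same kind of change as that from compound 1 to compound 2, but the place is not identical: there the methyl sits four bonds along the chain from a nitrogen on an aromatic ring, here three bonds along. Resting on the weakening seen in an at least 1.8-fold higher number from compound 1 to compound 2 (0.26 log units; that floor lies within the scatter), the step is expected to be a 2.0-fold higher number from compound 3 to compound 4 (0.31 log units; beyond the scatter), and compound 4 is estimated to give 30000 nM, between 10000 nM and 80000 nM.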

Compound 4, half-maximal inhibitory concentration: 22400 nM
Estimate against measurement, compound 4: 1.3-fold (0.13 log units) above; measured number inside the range.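

Set side by side in this assay, the added methyl reads as follows on the two cores: the same change on two cores in this assay, an at least 1.8-fold higher number (0.26 log units; that floor lies within the scatter) from compound 1 to compound 2 and a 1.5-fold higher number (0.18 log units; within the scatter) from compound 3 to compound 4; the limit leaves it open whether they differ The new step, a 1.5-fold higher number from compound 3 to compound 4 (0.18 log units; within the scatter), does not show that the methyl changes the number on the core of compound 3, and the earlier step, a floor set by a limit, shows no firm change on the core of compound 1 either. The pair therefore shows no conflict between the two cores, but it does not show that the change carries over with the same size.

As far as these compounds go, the step of a 2.4-fold lower number from compound 1 to compound 4 (0.38 log units; beyond the scatter), with vinyl in place of ethyl on a saturated chain carbon bound to an oxygen on an aromatic ring, does lie beyond the scatter, but it stands alone here, and whether it holds with other chains on the nitrogen stays open. Also open, from the compounds shown here alone, is how a longer chain, or a chain carrying an amine or a carboxylic acid, would read on either core.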